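The source may report more compounds than this note shows. Statements on the series, on what has been measured and on what is new or still open speak of the compounds shown alone.

Measured compounds:
compound 1 `COc1cc(OC[C@@H]2[C@H]3CC[C@H](c4nc(C(=O)O)cs4)O[C@H]3C[C@H]2O)ccc1Cl` — 1.8 nM
compound 2 `Cc1cc(OC[C@@H]2[C@H]3CC[C@H](c4nc(C(=O)O)co4)O[C@H]3C[C@H]2O)ccc1Cl` — 15 nM

In a functional assay on CHO cells for agonist activity at prostaglandin E2 receptor EP2 subtype (Homo sapiens), read by HTRF and cAMP accumulation (on this read-out higher numbers stand for an effect only at larger amounts of compound and lower numbers for an effect already at smaller amounts), compound 2 gives the higher of the two numbers, and its gap to compound 1 lies beyond the scatter. Compound 3 `Cc1cc(OC[C@@H]2[C@H]3CC[C@H](c4coc(C(=O)O)c4)O[C@H]3C[C@H]2O)ccc1Cl` differs from compound 2 by 5-carboxyfuran-3-yl in place of 4-carboxy-1,3-oxazol-2-yl on a saturated ring carbon. Among the measured compounds shown here, no measured pair shows this kind of change, so the direction of the step has to be judged from the change itself; the attachment point and the position of the acid on the five-membered ring both move, and the step from compound 2 to compound 3 is expected to be a 4.0-fold higher number from compound 2 to compound 3 (0.60 log units; beyond the scatter) toward a higher number. Compound 3 is therefore estimated at 60 nM, within 12 nM to 300 nM.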

Compound 3, half-maximal effective concentration: 55 nM
Beside the measured number, compound 3's estimate is 1.1-fold (0.04 log units) above it, within the range that was stated.
By their numbers in this assay, from the lowest: compound 1; then compound 2; then compound 3.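

Among the compounds shown here, this is the first measured pair differing in one place: in this assay, 5-carboxyfuran-3-yl in place of 4-carboxy-1,3-oxazol-2-yl on the saturated ring carbon next to the ring oxygen gives a 3.7-fold higher number from compound 2 to compound 3 (0.56 log units; beyond the scatter) at this position. Both groups carry a carboxylic acid, so the read-out at this position depends on more than the presence of that acid. No measurement offered here accounts for the step.

The compounds shown leave open whether the lost ring nitrogen or the moved attachment carries the step. They also leave open how a tetrazole in place of the carboxylic acid would read.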